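The source may report more compounds than this note shows. Statements on the series, on what has been measured and on what is new or still open speak of the compounds shown alone.

Going by the values given here, in an ADME assay on microsomes (Homo sapiens) for metabolic stability (a lower number here means that the compound disappears faster, a higher number that the compound lasts longer), three compounds have numbers so far. Compound 1 `O=C(c1ccccc1)N1CCC(C(=O)N2N=CCC2c2ccccc2)CC1` gives 1.72 h, compound 2 `CC(C)(C)C(=O)N1CCSC1c1ccccc1` gives 0.3 h, and compound 3 `O=C(C1CCCC1)N1N=CCC1c1ccccc1` gives 1.13 h. Compound 3 thus stands within the scatter of compound 1 and clearly above compound 2. Compound 4 `CC(C)C(=O)N1N=CCC1c1ccccc1` differs from compound 3 in one place, with isopropyl in place of cyclopentyl on a carbonyl carbon. Among the compounds with values here, no pair of measured compounds shows this kind of change, so the data offer no direct guide. The starting point is compound 3 with 1.13 h. No shift beyond the scatter is expected from that starting point. The expected change is a 1.1-fold lower number from compound 3 to compound 4 (0.05 log units; within the scatter). For compound 4 the estimated half-life is 1 h, with an expected range of 0.5 h to 2 h.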

Compound 4, half-life: > 1.5 h
Compound 4: a limit, no number; the forecaster's own chance of this, stated with the estimate: 3%; middle value at least 1.5-fold (0.17 log units) from the limit.
By their numbers in this assay, from the lowest: compound 2; then compounds 3 and 1 (each within the scatter of the next).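

In this assay compound 4 gives > 1.5 h, which is a limit of the assay and not a number. Isopropyl in place of cyclopentyl on a carbonyl carbon gives an at least 1.3-fold higher number from compound 3 to compound 4 (0.12 log units; that floor lies within the scatter), so at this position the ring of carbon can go without the number falling. The true size of the step cannot be read, only its floor: the limit of > 1.5 h in this assay, at which 1 of the 4 values shown sits.

As far as these compounds go, what stays open is how far the number lies past that limit, and how a longer chain, an amine or a carboxylic acid would behave on the same carbonyl carbon.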